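The compounds below may be only part of what the source reports. "The series", "measured", "known", "first", "only" and "open" are said of these compounds alone.

Measured compounds:
compound 1 `COc1ccc(C2=NN(C(=O)c3ccc4c(c3)OCCO4)C(c3ccc(F)cc3)C2)cc1`, 3780 nM
compound 2 `COc1ccc(C2=NN(C(=O)C3COc4ccccc4O3)C(c3ccc(OC)cc3)C2)cc1`, 11000 nM

In a functional assay on WM 266-4 cells (Homo sapiens) for inhibition, read by MTT assay, with a stated time of 24 h (on this read-out lower numbers stand for stronger inhibition of growth and higher numbers for weaker inhibition of growth), compound 1 gives the lowest number of the two; compound 2 gives the higher number in this assay, a gap beyond the scatter. Compound 3 `COc1ccc(C2=NN(C(=O)c3ccc4c(c3)OCCO4)C(c3ccccc3)C2)cc1` is not yet measured. It differs from compound 1 by hydrogen in place of fluoro on an aromatic carbon. For the measured compounds named here, no measured pair shows this change, so only a small step is expected, a 1.4-fold higher number from compound 1 to compound 3 (0.14 log units; within the scatter), leaning toward a somewhat higher number but plausibly none beyond the scatter. Compound 3 is expected at 5200 nM, with a range from 2200 nM to 13000 nM.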

Compound 3, concentration for 50% growth inhibition: 2370 nM
The estimate for compound 3 lay 2.2-fold (0.34 log units) above the measured number; measured number inside the range.
By their numbers in this assay, from the lowest: compounds 3 and 1 (each within the scatter of the next); then compound 2.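

In this assay, for the compounds shown here, the change from 4-fluorophenyl to phenyl gives a 1.6-fold lower number from compound 1 to compound 3 (0.20 log units; within the scatter) and is the first single-place comparison. Fluoro and hydrogen at this position therefore cannot be told apart on this read-out, and the activity of compound 1 does not depend on the fluoro. Nothing available explains this outcome.

Open, on these data alone, is whether an amine or a carboxylic acid on this aromatic carbon would move the number beyond the scatter. Compound 2 differs from compound 1 in more than one place, so it cannot answer this.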